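Triazole esters: 2-fluorophenyl in place of 3-chlorophenyl

The source may hold more compounds than are shown below. What is called first, only, known or untested is meant among the compounds shown, and "the series" means these compounds.

For the measured compounds named here, in a functional assay on A549 cells (Homo sapiens) for antiproliferative activity, read by MTT assay, with a stated time of 48 h (on this read-out higher numbers stand for weaker inhibition and lower numbers for stronger inhibition), compound 3 `C/C(=C\CC/C(C)=C/CC[C@@H]1[C@@]2(C)CCC(=O)C(C)(C)[C@H]2CC[C@@]1(C)O)CC/C=C(\C)C(=O)OCc1cn(-c2cccc(Cl)c2)nn1` gives 147000 nM, the only actual number so far. Compound 1 `C/C(=C\CC/C(C)=C/CC[C@@H]1[C@@]2(C)CCC(=O)C(C)(C)[C@H]2CC[C@@]1(C)O)CC/C=C(\C)C(=O)OCc1cn(-c2ccc(F)cc2)nn1` reaches only a limit, > 150000 nM. Compound 2 `COc1ccc(-n2cc(COC(=O)/C(C)=C/CC/C(C)=C/CC/C(C)=C/CC[C@@H]3[C@@]4(C)CCC(=O)C(C)(C)[C@H]4CC[C@@]3(C)O)nn2)cc1` likewise reaches only a limit, > 150000 nM.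

Unmeasured compound 4 `C/C(=C\CC/C(C)=C/CC[C@@H]1[C@@]2(C)CCC(=O)C(C)(C)[C@H]2CC[C@@]1(C)O)CC/C=C(\C)C(=O)OCc1cn(-c2ccccc2F)nn1` differs from compound 3 as follows: 2-fluorophenyl in place of 3-chlorophenyl on an aromatic nitrogen. In words, 2-fluorophenyl stands in place of 3-chlorophenyl on an aromatic nitrogen.

Going by the values given here, two measured steps bear on this change: an at least 1.0-fold lower number from compound 1 to compound 3 (0.00 log units; that floor lies within the scatter) and an at least 1.0-fold lower number from compound 2 to compound 3 (0.00 log units; that floor lies within the scatter). Both rest on (the limit of > 150000 nM in this assay, at which 2 of the 3 values shown sit). No step beyond the scatter is expected in this assay. The step expected is a 1.1-fold lower number from compound 3 to compound 4 (0.02 log units; within the scatter). The estimate for compound 4 is 140000 nM, with an expected range of 70000 nM to 280000 nM.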

Compound 4, half-maximal inhibitory concentration: > 150000 nM
Compound 4 ended at the assay's limit (the forecaster's own chance of this, stated with the estimate: 55%); middle value at least 1.0-fold (0.02 log units) away from the limit.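

In this assay, for the compounds shown here, 2-fluorophenyl in place of 3-chlorophenyl on the aromatic nitrogen gives no step that can be told from the scatter: an at least 1.0-fold higher number from compound 3 to compound 4 (0.00 log units; that floor lies within the scatter). The steps to compound 4 from compound 1 and from compound 2 cannot be read. Compound 4 now shares a limit, not a number, with compound 1 and compound 2, which leaves compound 3 as the only compound with a number: the limit of > 150000 nM in this assay, at which 3 of the 4 values shown sit.

From the compounds shown here alone, how far past the limit these compounds lie stays open. Also open, going by these compounds, is whether an amine or a carboxylic acid on the phenyl ring, in place of the halogen, would give a value clear of the limit.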